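Changing the Ring on the Sulfonyl Sulfur Again

A few compounds are considered here, and "the series" means these few. Any claim that something is new, unique, unknown or untested is made for them only; others in the source may bear on it.

Compound 1 `Cc1nc(C)c(S(=O)(=O)NC(=O)NC/C=C2\CCCc3cnn(Cc4ccc(Cl)cc4Cl)c32)s1` and compound 2 `Cn1cc(S(=O)(=O)NC(=O)NC/C=C2\CCCc3cnn(Cc4ccc(Cl)cc4Cl)c32)cn1` share one core and differ only in the ring attached to the sulfonyl sulfur. In a functional assay on CHO-K1 cells for antagonist activity at prostaglandin E2 receptor EP3 subtype (Homo sapiens), read by TR-FRET and cAMP accumulation, with a stated time of 30 min (a lower number here means a stronger inhibitor, a higher number a weaker inhibitor), compound 1 gives 4 nM and compound 2 gives 8 nM; the step of a 2.0-fold higher number from compound 1 to compound 2 (0.30 log units; within the scatter) lies within the scatter, so compound 2 sits at one end of the two numbers without being truly apart from compound 1. Compound 3 `Cc1ncc(S(=O)(=O)NC(=O)NC/C=C2\CCCc3cnn(Cc4ccc(Cl)cc4Cl)c32)s1` carries 2-methyl-1,3-thiazol-5-yl in place of 1-methyl-1H-pyrazol-4-yl on a sulfonyl sulfur. Among the compounds with values here, the only step that bears on this change is the one from compound 1 to compound 2, which stayed within the scatter, so for compound 3 the step of a 1.6-fold lower number from compound 2 to compound 3 (0.20 log units; within the scatter) is expected to stay within the scatter as well. Compound 3 is estimated to give 5 nM, between 2 nM and 12 nM.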

Compound 3, half-maximal inhibitory concentration: 9 nM
The estimate for compound 3 lay 1.8-fold (0.26 log units) below the measured number, within the range that was stated.
By their numbers in this assay, from the lowest: compounds 1, 2 and 3 (each within the scatter of the next, the first and the last beyond it).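

Putting 2-methyl-1,3-thiazol-5-yl in place of 1-methyl-1H-pyrazol-4-yl on the sulfonyl sulfur gives a 1.1-fold higher number from compound 2 to compound 3 (0.05 log units; within the scatter), so these two different rings cannot be told apart in this assay. Hydrogen in place of methyl on an aromatic carbon of the thiazole gives a 2.3-fold higher number from compound 1 to compound 3 (0.35 log units; beyond the scatter), the first step in this set to pass the scatter, though only modestly. This shows that a single methyl on this ring can register, even though the ring exchange did not.

From the compounds shown here alone, whether a phenyl ring or a cyclopropyl group on the sulfonyl sulfur would stay in this range remains open. Nothing available explains either step.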